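A few compounds are considered here, and "the series" means these few. Any claim that something is new, unique, unknown or untested is made for them only; others in the source may bear on it.

Compound 1 `COc1cc2c(cc1OC)C(CC(=O)Nc1cccc(Cl)c1)CC2`: 51.5%
Compound 2 `COc1cc2c(cc1OC)C(CC(=O)Nc1ccc(C)cc1)CC2`: 41.4%
Compound 3 `COc1cc2c(cc1OC)C(CC(=O)Nc1ccccn1)CC2`: 48.1%

All three compounds share one core and differ only in the group attached to the amide-type nitrogen. They were tested in a functional assay on the whole organism (strain Swiss Albino) for inhibition, with Mus musculus as the target, in the writhing test, with a stated time of 1 h, at a dose of 100 mg/kg by the oral route; a lower number here means less inhibition, a higher number more inhibition at the dose given (going by the name of the read-out). Compound 3 holds the second highest of the three numbers: the step of a number 3.4 percentage points lower from compound 1 to compound 3 (within the scatter) separates it from compound 1, and the step of a number 6.7 percentage points higher from compound 2 to compound 3 (within the scatter) from compound 2. Among the measured compounds shown here, only one measured step is larger than the scatter, namely a number 10.1 percentage points lower from compound 1 to compound 2 (beyond the scatter), and even that is described as modest.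

Compound 4 `COc1cc2c(cc1OC)C(CC(=O)Nc1cccnc1)CC2` has the same atoms as compound 3, joined differently: pyridin-3-yl in place of pyridin-2-yl on an amide-type nitrogen. For the measured compounds named here, no measured step swaps one pyridyl for another, so the three known steps bear on it only indirectly: each of them exchanges the whole group on the amide-type nitrogen, and the largest of them is still modest. A rearrangement within the same ring would therefore be expected to move the number no further than that, and most likely not beyond the scatter. The expected step is a number 2.1 percentage points lower from compound 3 to compound 4 (within the scatter).

For compound 4 the estimate in this assay is 46%, with a range from 34% to 58%.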

Compound 4, a percentage reported as inhibition, in the whole organism at one dose (the size of the read-out at that dose, not a potency): 70.7%
For compound 4 the middle estimate is 24.7 percentage points below the measured one, outside the stated range (above it).
By their numbers in this assay, from the lowest: compounds 2, 3 and 1 (each within the scatter of the next, the first and the last beyond it); then compound 4.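

Swapping pyridin-2-yl for pyridin-3-yl on the amide-type nitrogen keeps the same atoms and the same counted features, yet in this assay it gives a number 22.6 percentage points higher from compound 3 to compound 4 (beyond the scatter). This position therefore responds to how the pyridine ring is joined to the amide-type nitrogen, not only to which atoms the group contains, and that rearrangement outweighs every exchange among the first three groups. Compound 4 also clears both phenyl-bearing compounds, with a number 19.2 percentage points higher from compound 1 to compound 4 (beyond the scatter) and a number 29.3 percentage points higher from compound 2 to compound 4 (beyond the scatter), which makes it the highest of the four beyond the scatter, though nothing available accounts for the jump.

The compounds shown leave open whether the rise is particular to pyridin-3-yl or would also appear with pyridin-4-yl, and whether a methyl group, a chlorine or an amine on the pyridin-3-yl ring would keep it. Going by these compounds, each number is also a single reading at one dose, so it remains open how compound 4 would compare with compound 3 across a range of doses.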